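Methoxyphenyl in place of dihydroxyphenyl on a shared core

The source may report more compounds than this note shows. Statements on the series, on what has been measured and on what is new or still open speak of the compounds shown alone.

Measured compounds:
Compound 1, `CCOC(=O)C1=C(Nc2ccccc2)S/C(=C\c2ccccc2)C1=O`: 29.6%
Compound 2, `CCOC(=O)C1=C(Nc2ccccc2)S/C(=C\c2ccc(O)c(O)c2)C1=O`: 30.7%

In a functional assay on A549 cells (Homo sapiens) for inhibition, read by MTT assay, with a stated time of 72 h, tested at 10 uM (a lower number here means less inhibition, a higher number more inhibition at the concentration tested (going by the name of the read-out)), compound 2 stands at 30.7%, and compound 1 sits close by at 29.6%. Among the compounds with values here, the only step so far, a number 1.1 percentage points higher from compound 1 to compound 2 (within the scatter), separates the two, so on these numbers they cannot be told apart.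

Compound 3, `CCOC(=O)C1=C(Nc2ccccc2)S/C(=C\c2ccc(OC)cc2)C1=O`, has not yet been measured. It differs from compound 2 in one place: 4-methoxyphenyl in place of 3,4-dihydroxyphenyl on a double-bonded chain carbon bound to a double-bonded ring carbon. Within the data shown here, the single step that bears on this change is the one from compound 1 to compound 2, which also exchanged one aromatic group for another at the same place and produced a number 1.1 percentage points higher from compound 1 to compound 2 (within the scatter), a shift inside the scatter. With nothing else to go on, no step beyond the scatter is expected here either; the expected step of a number 0.7 percentage points lower from compound 2 to compound 3 (within the scatter) is small. Compound 3 is therefore estimated to give 30% in this assay, with a range from 18% to 42%.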

Compound 3, a percentage reported as inhibition, at one concentration (the size of the read-out at that concentration, not a potency): 17.5%
Compound 3: the middle estimate sits 12.5 percentage points above what was measured; the measured number lies below the stated range.
By their numbers in this assay, from the lowest: compound 3; then compounds 1 and 2 (each within the scatter of the next).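

Methoxy in place of hydrogen on an aromatic carbon gives a number 12.1 percentage points lower from compound 1 to compound 3 (beyond the scatter) in this assay and 4-methoxyphenyl in place of 3,4-dihydroxyphenyl gives a number 13.2 percentage points lower from compound 2 to compound 3 (beyond the scatter) in the same test. The group on the double-bonded chain carbon therefore can change the read-out, even though phenyl and 3,4-dihydroxyphenyl could not be told apart there. Nothing available explains why the methoxy group lowers the number.

Within the data shown here, with only three compounds, this single methoxy example cannot show how far the effect extends to other groups. From the compounds shown here alone, it remains open whether an ethoxy group, a lone hydroxy group, an amine or a carboxylic acid on that aromatic ring would give a number near those of compound 1 and compound 2 or one near that of compound 3.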